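Moving the Methoxy Group on a Receptor Ligand

The source may report more compounds than this note shows. Statements on the series, on what has been measured and on what is new or still open speak of the compounds shown alone.

The measured compounds, each with its number in an assay for displacement of a labelled ligand from melanin-concentrating hormone receptor 1 (Homo sapiens), read by fluorescence; on this read-out lower numbers stand for stronger inhibition and higher numbers for weaker inhibition:

Compound 1 `CC(=O)Nc1cccc(C2CCN(CCCn3c(-c4ccccc4)nc4ccccc43)CC2)c1` gives 2 nM in this assay.
Compound 2 `CC(=O)Nc1cccc(C2CCN(CCCn3c(-c4cccc(Cl)c4)nc4ccccc43)CC2)c1` gives 5 nM in this assay.
Compound 3 `COc1ccccc1-c1nc2ccccc2n1CCCN1CCC(c2cccc(NC(C)=O)c2)CC1` gives 747 nM in this assay.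

Compound 3 has the highest number of the three in this assay, that is, the weakest inhibition. The nearest is compound 2, with a 150-fold higher number from compound 2 to compound 3 (2.17 log units; beyond the scatter), and the furthest is compound 1, with a 370-fold higher number from compound 1 to compound 3 (2.57 log units; beyond the scatter).

Compound 4 `COc1ccc(-c2nc3ccccc3n2CCCN2CCC(c3cccc(NC(C)=O)c3)CC2)cc1` has the same atoms as compound 3, joined differently: 4-methoxyphenyl in place of 2-methoxyphenyl on an aromatic carbon. Among the measured compounds shown here, no measured step compares these two methoxyphenyl groups directly, so the expectation rests on two indirect steps. Adding a methoxy group to give compound 3 was a large step, a 370-fold higher number from compound 1 to compound 3 (2.57 log units; beyond the scatter), while adding a chloro group at another place, a 2.5-fold higher number from compound 1 to compound 2 (0.40 log units; beyond the scatter), was only modest. From three compounds it cannot be told whether the large loss seen with compound 3 goes with the methoxy group itself or with where it sits; the modest chloro step leaves room for a substantial recovery once the methoxy group is moved, but not a certain one.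

Balancing these, compound 4 is expected to give 20 nM in this assay, within 4 nM to 100 nM. That estimate corresponds to an expected step of a 37-fold lower number from compound 3 to compound 4 (1.57 log units; beyond the scatter).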

Compound 4, half-maximal inhibitory concentration: 9 nM
Compound 4: middle estimate off by 2.2-fold (0.35 log units), on the high side, and the stated range covers the measured number.
By their numbers in this assay, from the lowest: compound 1; then compounds 2 and 4 (each within the scatter of the next); then compound 3.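

In this assay, moving the methoxy group from the 2-methoxyphenyl to the 4-methoxyphenyl arrangement gives an 83-fold lower number from compound 3 to compound 4 (1.92 log units; beyond the scatter), so the large loss seen with compound 3 cannot belong to the methoxy group alone and depends on where the group sits on the phenyl ring. The 4-methoxyphenyl group still gives a 4.5-fold higher number from compound 1 to compound 4 (0.65 log units; beyond the scatter) when set against the unsubstituted phenyl ring, a modest cost, while the comparison with the 3-chlorophenyl group gives a 1.8-fold higher number from compound 2 to compound 4 (0.26 log units; within the scatter), so these two substituted rings cannot be told apart in this assay. No measurement at hand bears on why the place of the methoxy group matters so much.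

The compounds shown leave open whether the sharp loss belongs to methoxy in particular or would also follow a chloro group, a fluoro group or an amine placed where the methoxy group sits in compound 3. They also leave open how far a larger ether such as ethoxy, or a carboxylic acid, would be tolerated where the methoxy group sits in compound 4.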